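A few compounds are considered here, and "the series" means these few. Any claim that something is new, unique, unknown or untested is made for them only; others in the source may bear on it.

Working notes on the series. Compound 1 `CCS(=O)(=O)CCC12CCC(c3nnc(-c4ccccc4C)n3C)(CC1)CC2`, compound 3 `CCS(=O)(=O)CCC12CCC(c3nnc(-c4ccccc4Br)n3C)(CC1)CC2` and compound 2 `Cn1c(-c2ccccc2C(F)(F)F)nnc1C12CCC(CNS(C)(=O)=O)(CC1)CC2` share one saturated core. In an assay on CHO-K1 cells for inhibition of 11-beta-hydroxysteroid dehydrogenase type 2 (Homo sapiens), read by scintillation proximity assay (a higher number here means a weaker inhibitor, a lower number a stronger inhibitor), compound 1 gives only a limit, > 4000 nM. Compound 3 likewise gives only a limit, > 4000 nM. Compound 2 also gives only a limit, > 4000 nM, and so stands level with the other two measured compounds without any readable number. Among the compounds with values here, the single step between measured compounds, a step that the two limits leave unreadable from compound 1 to compound 3, cannot be sized because of the limit of > 4000 nM in this assay, at which 3 of the 3 values shown sit. Compound 4 `CC(O)CCCC12CCC(c3nnc(-c4ccccc4C(F)(F)F)n3C)(CC1)CC2` differs from compound 2 by 3-hydroxybutyl in place of methanesulfonamido on a saturated chain carbon bound to a saturated ring carbon. Within the data shown here, no measured step bears on this change, and no measured compound reaches a number. Compound 4 is expected to stay at the limit, so the step that the limit leaves unreadable from compound 2 to compound 4 is expected to remain unreadable. The estimate for compound 4 is 8000 nM, with a range from 2500 nM to 30000 nM.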

Compound 4, half-maximal inhibitory concentration: > 1000 nM
Compound 4 gave a limit, no number; the forecaster's own chance of this, stated with the estimate: 75%; the middle value is on the limit's open side.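

The step between compound 2 and compound 4 cannot be read: each of the two compounds gives only a limit. The compounds shown leave open whether any change on the shared core gives a readable number in this assay.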